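One Methyl Removed, Twice: A Small Step Repeated

This account rests on a few compounds, and the source may have more. Where it says the series, first, only, none or still open, it means among the compounds named here.

Measured compounds:
compound 1, `Cc1ncc2c(n1)CCN(C)C2`: 45%
compound 2, `CN1CCc2ncncc2C1`: 50%
compound 3, `Cc1ncc(-c2ccccc2)c(C(C)(C)C)n1`: 22%

In a functional assay on the whole organism for inhibition, with Rattus norvegicus as the target, with stated times of 1 h and 3.5 h, at a dose of 100 mg/kg by the oral route (on this read-out higher numbers stand for more inhibition at the one dose given (going by the name of the read-out) and lower numbers for less inhibition), compound 1 gives 45% and compound 2 gives 50%. Compound 2 differs from compound 1 by hydrogen in place of methyl on an aromatic carbon, and the step is a number 5 percentage points higher from compound 1 to compound 2 (within the scatter). Compound 3 gives 22% in this assay, the lowest of the three; the difference between its core and the core of compound 1 is not broken down here. Compound 4, `CC(C)(C)c1ncncc1-c1ccccc1`, differs from compound 3 by hydrogen in place of methyl on an aromatic carbon. This is the same kind of change as that from compound 1 to compound 2, though here the ring is not part of a fused system and the position is meta to a tert-butyl group and para to a group of 6 heavy atoms. Because a number 5 percentage points higher from compound 1 to compound 2 (within the scatter) lies within the scatter, the expected step is a number 3 percentage points higher from compound 3 to compound 4 (within the scatter). Compound 4 is thus estimated at 25% in this assay, likely between 10% and 42%.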

Compound 4, a percentage reported as inhibition, in the whole organism at one dose (the size of the read-out at that dose, not a potency): 48%
The estimate for compound 4 lay 23 percentage points below the measured number, and the stated range ends below it.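

In this assay, putting hydrogen in place of the methyl on an aromatic carbon gives a number 26 percentage points higher from compound 3 to compound 4 (beyond the scatter) and so shows that this change does not bring a step of one fixed size to both cores: the same change on two cores in this assay, a number 5 percentage points higher (within the scatter) from compound 1 to compound 2 and a number 26 percentage points higher (beyond the scatter) from compound 3 to compound 4, 21 percentage points apart, beyond the scatter of two such steps. The size of the step therefore cannot be carried from the core of compound 1 to the core of compound 3. Two pairs do not show which difference between the cores sets the size, nor what the change would do on a third core.

The compounds shown carry only hydrogen or methyl at this ring position, leaving open how an amine or a longer chain would fare there. On these data alone, each compound is also seen at a single dose, so the effect of the change at other doses remains open.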